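A few compounds are considered here, and "the series" means these few. Any claim that something is new, unique, unknown or untested is made for them only; others in the source may bear on it.

Compound 1 `CCC(COc1cccc(Cl)c1)OC(=O)NCc1ccccc1` gives > 100000 nM in an assay for inhibition of zeta-carotene desaturase, chloroplastic/chromoplastic (Capsicum annuum), using a Dixon plot, with a stated time of 8 h (a higher number here means a weaker inhibitor, a lower number a stronger inhibitor), which is a limit.
Compound 2 `CCC(COc1cccc(C(=O)O)c1)OC(=O)NCc1ccccc1` gives > 100000 nM in this assay, again a limit.

For the measured compounds named here, compound 1 therefore stands only at a limit, and so does the one other value, (the limit of > 100000 nM in this assay, at which 2 of the 2 values shown sit). Going by the values given here, the single measured step, a step that the two limits leave unreadable from compound 1 to compound 2, is unreadable between two limits. Compound 3 `CCC(COc1cccc(Cl)c1)OC(=O)NC(C)c1ccccc1` differs from compound 1 by methyl in place of hydrogen on a saturated chain carbon bound to an amide-type nitrogen and an aromatic carbon. Among the compounds with values here, no measured step bears on this change, so no direction can be set for it. Compound 3 is expected at 150000 nM, range 50000 nM to 500000 nM, most likely reported again as a limit. The step that the limit leaves unreadable from compound 1 to compound 3 is expected to stay unreadable.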

Compound 3, half-maximal inhibitory concentration: > 100000 nM
Compound 3 gave a limit, no number (the forecaster's own chance of this, stated with the estimate: 85%); the middle value is on the limit's open side.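

Compound 1 and compound 3 both stand only at a limit, and no step can be read between them: the limit of > 100000 nM in this assay, at which 3 of the 3 values shown sit.

The compounds shown leave open which change to the shared core, if any, gives a measurable value in this assay.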